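The compounds below may be only part of what the source reports. "The series", "measured", "known", "first", "only" and "open" are said of these compounds alone.

Measured in an ADME assay on L929 cells (Mus musculus) for cytotoxicity, read by resazurin assay, with a stated time of 72 h; on this read-out higher numbers stand for weaker inhibition and lower numbers for stronger inhibition:
Compound 1 `O=C(/C=C/c1ccc2c(c1)B(O)OC2)c1ccc(F)cc1`: > 10 ug/mL (a limit)
Compound 2 `COCOc1ccccc1C(=O)/C=C/c1ccc2c(c1)B(O)OC2`: 9.02 ug/mL

In this assay, for the measured compounds named here, compound 2 has the only actual number (9.02 ug/mL). Compound 3 `O=C(/C=C/c1ccc2c(c1)B(O)OC2)c1ccccc1F` has fluoro in place of methoxymethoxy on an aromatic carbon, ortho to a large group (fluoro in place of methoxymethoxy on an aromatic carbon). Going by the values given here, no measured step covers this change. Compound 1 also carries fluoro, and its value (> 10 ug/mL) is a limit. On that basis, the expected step is small and toward weaker inhibition (a 1.2-fold higher number from compound 2 to compound 3 (0.09 log units; within the scatter)). Compound 3 is estimated at 11 ug/mL (expected range 6 ug/mL to 25 ug/mL).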

Compound 3, half-maximal inhibitory concentration: > 10 ug/mL
Compound 3 ended at the assay's limit (the forecaster's own chance of this, stated with the estimate: 55%); the middle value lies beyond the limit too.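

In this assay, going by these compounds, fluoro in place of methoxymethoxy on this aromatic carbon, ortho to a large group, gives an at least 1.1-fold higher number from compound 2 to compound 3 (0.04 log units; that floor lies within the scatter), so the real size of the change remains unknown. The step from compound 1 to compound 3 cannot be read, as both values are limits. With fluoro on this carbon, compound 3 joins compound 1 at the limit of the assay: the limit of > 10 ug/mL in this assay, at which 2 of the 3 values shown sit.

On these data alone, how far beyond that limit either fluoro compound lies remains open. So does the effect of an amine, a carboxylic acid or a longer chain at this place.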